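This account rests on a few compounds, and the source may have more. Where it says the series, first, only, none or still open, it means among the compounds named here.

Going by the values given here, the three compounds measured so far share one core and differ only in the ring attached to the thiocarbonyl carbon. In a functional assay on A-375 cells (Homo sapiens) for antiproliferative activity, read by CCK-8 assay, with a stated time of 72 h, tested at 8 uM (a higher number here means a stronger effect of the compound at the concentration tested, a lower number a weaker effect), compound 1 `CC1CCCCN1C(=S)SCc1ccc(C(=O)Nc2ccccc2N)cc1` gives 85.2%, compound 2 `CC1CCN(C(=S)SCc2ccc(C(=O)Nc3ccccc3N)cc2)CC1` gives 87.4%, and compound 3 `Nc1ccccc1NC(=O)c1ccc(CSC(=S)N2CCc3cc(Cl)ccc32)cc1` gives 82.3%. Compound 3 holds the smallest of the three numbers, but each gap to it lies within the scatter: a number 2.9 percentage points lower from compound 1 to compound 3 (within the scatter) and a number 5.1 percentage points lower from compound 2 to compound 3 (within the scatter), while a number 2.2 percentage points higher from compound 1 to compound 2 (within the scatter).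

Compound 4 `Nc1ccccc1NC(=O)c1ccc(CSC(=S)N2CCCC2)cc1` is not yet measured. Its change from compound 3 is pyrrolidin-1-yl in place of 5-chloro-2,3-dihydro-1H-indol-1-yl on a thiocarbonyl carbon. All three measured steps bear on this, since each also swaps the ring on the thiocarbonyl carbon, and none of them moved the number beyond the scatter. The exchange of the 5-chloro-2,3-dihydro-1H-indol-1-yl group for a smaller saturated ring therefore gives no reason to expect a step beyond the scatter in this assay, in either direction; the expected step is a number 2.7 percentage points higher from compound 3 to compound 4 (within the scatter). Compound 4 is estimated at 85%, within a range from 75% to 93%.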

Compound 4, a percentage reported as inhibition, at one concentration (the size of the read-out at that concentration, not a potency): 89.5%
Compound 4: the middle estimate sits 4.5 percentage points below what was measured; measured number inside the range.
By their numbers in this assay, from the lowest: compounds 3, 1, 2 and 4 (each within the scatter of the next).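

In this assay, the ring on the thiocarbonyl carbon can go from 10 heavy atoms in 5-chloro-2,3-dihydro-1H-indol-1-yl to 5 in pyrrolidin-1-yl, losing the aromatic ring and the chlorine, and the result is still a number 7.2 percentage points higher from compound 3 to compound 4 (within the scatter) and so no real change. The comparisons with the two methylpiperidine compounds agree, with a number 2.1 percentage points higher from compound 2 to compound 4 (within the scatter) and a number 4.3 percentage points higher from compound 1 to compound 4 (within the scatter), so none of the four rings at this position stands apart from the others. Nothing measured here explains why these numbers stay so close.

Still open, going by these compounds, is whether a group of another kind on the thiocarbonyl carbon, such as a piperazine ring with its second nitrogen or an open-chain diethylamino group, would move the number beyond the scatter. A read-out at one concentration also leaves open whether these four compounds differ in potency.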